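Swapping the five-membered ring on compound 3 for methylpiperazine

This account rests on a few compounds, and the source may have more. Where it says the series, first, only, none or still open, it means among the compounds named here.

Compound 3 `Cc1nc(-c2cc(C(F)(F)F)ccc2[C@H]2CCOc3cc(S(=O)(=O)Nc4nccs4)ccc32)co1` gives 2.9 in a physicochemical assay for lipophilicity (a higher number here means a more lipophilic compound, a lower number a more polar compound), the second highest of three numbers. Compound 1 `O=S(=O)(Nc1nccs1)c1ccc2c(c1)OCC[C@@H]2c1ccc(C(F)(F)F)cc1-c1nccs1` gives 3.3, and compound 2 `O=S(=O)(Nc1nccs1)c1ccc2c(c1)OCC[C@@H]2c1ccc(C(F)(F)F)cc1-n1ccnn1` gives 2.3; the step of a number 0.40 log units lower from compound 1 to compound 3 (beyond the scatter) and the step of a number 0.60 log units higher from compound 2 to compound 3 (beyond the scatter) are both beyond the scatter. Compound 4 `CN1CCN(c2cc(C(F)(F)F)ccc2[C@H]2CCOc3cc(S(=O)(=O)Nc4nccs4)ccc32)CC1` differs from compound 3 in one place: 4-methylpiperazin-1-yl in place of 2-methyl-1,3-oxazol-4-yl on an aromatic carbon. For the measured compounds named here, three measured steps bear on this position, each exchanging one five-membered aromatic ring for another: a number 1.00 log units lower from compound 1 to compound 2 (beyond the scatter), a number 0.40 log units lower from compound 1 to compound 3 (beyond the scatter) and a number 0.60 log units higher from compound 2 to compound 3 (beyond the scatter). None tests a six-membered non-aromatic ring, so the expectation rests on their modest sizes. He expects a modest downward step, a number 0.60 log units lower from compound 3 to compound 4 (beyond the scatter), in this assay. Compound 4 is therefore estimated at 2.3, between 1.7 and 2.9.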

Compound 4, distribution coefficient: 2.1
Compound 4: middle estimate off by 0.20 log units, on the high side; measured number inside the range.
By their numbers in this assay, from the lowest: compounds 4 and 2 (each within the scatter of the next); then compound 3; then compound 1.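

In this assay, for the compounds shown here, the first non-aromatic six-membered ring at this position gives a number 0.80 log units lower from compound 3 to compound 4 (beyond the scatter) and a number 1.20 log units lower from compound 1 to compound 4 (beyond the scatter), the first large step here. Yet a number 0.20 log units lower from compound 2 to compound 4 (within the scatter) means that the 4-methylpiperazin-1-yl ring cannot be separated from the 1H-1,2,3-triazol-1-yl ring, so leaving the aromatic five-membered rings does not by itself carry the number past what one of them already reaches. Nothing measured here explains these steps. From the compounds shown here alone, whether a morpholine ring or an open-chain dimethylamino group on this aromatic carbon would fall with compound 4 or with compound 3 stays open.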